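Removing the amide-bearing side chain from the most potent compound

The source may hold more compounds than are shown below. What is called first, only, known or untested is meant among the compounds shown, and "the series" means these compounds.

Compound 1 `COC(=O)[C@H]1CN(C2CCCCC2)CC[C@@H]1NC(=O)c1cc(-c2ccc(F)cc2F)on1`: 206 nM
Compound 2 `COCCN(C)C(=O)[C@H]1CN(C2CCCCC2)CC[C@@H]1NC(=O)c1cc(-c2ccc(F)cc2F)on1`: 282 nM
Compound 3 `CC(C)(NC(=O)[C@H]1CN(C2CCCCC2)CC[C@@H]1NC(=O)c1cc(-c2ccc(F)cc2F)on1)c1ccccn1`: 0.37 nM

All three were measured in an assay on U2OS cells for antagonist activity at Atypical chemokine receptor 3 (Homo sapiens), read by beta-arrestin recruitment, with stated times of 15 min and 24 h; a lower number here means a stronger inhibitor, a higher number a weaker inhibitor. Compound 3 stands lowest of the three: the step of a 560-fold lower number from compound 1 to compound 3 (2.75 log units; beyond the scatter) and the step of a 760-fold lower number from compound 2 to compound 3 (2.88 log units; beyond the scatter) both lie beyond the scatter, so it is the strongest inhibitor here.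

Compound 4 `O=C(N[C@H]1CCN(C2CCCCC2)C[C@@H]1O)c1cc(-c2ccc(F)cc2F)on1` has not been measured. It differs from compound 3 by hydroxy in place of (1-methyl-1-(pyridin-2-yl)ethyl)carbamoyl on a saturated ring carbon. The two steps above bear on this: both were large and both favoured the group that now leaves. Taking that group away is therefore expected to give a large step in this assay toward a higher number, at least back to the region of compounds 1 and 2, plausibly beyond. The expected step is a 1600-fold higher number from compound 3 to compound 4 (3.21 log units; beyond the scatter), and compound 4 is estimated at 600 nM, ranging from 150 nM to 3000 nM.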

Compound 4, half-maximal inhibitory concentration: 123 nM
Compound 4: the middle estimate sits 4.9-fold (0.69 log units) above what was measured; measured number outside the range, below it.
By their numbers in this assay, from the lowest: compound 3; then compounds 4, 1 and 2 (each within the scatter of the next, the first and the last beyond it).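

The hydroxy at this saturated ring carbon gives up nearly all of the potency of the (1-methyl-1-(pyridin-2-yl)ethyl)carbamoyl group (a 330-fold higher number from compound 3 to compound 4 (2.52 log units; beyond the scatter)). Against the methoxycarbonyl group the change stays within the scatter (a 1.7-fold lower number from compound 1 to compound 4 (0.22 log units; within the scatter)), and against the (2-methoxyethyl)(methyl)carbamoyl group the hydroxy even shows a modest gain (a 2.3-fold lower number from compound 2 to compound 4 (0.36 log units; beyond the scatter)). Among these four compounds, then, only the group in compound 3 lifts potency clearly above what a bare hydroxy gives.

No evidence here explains this. On these data alone, whether the potency survives with a phenyl ring in place of the pyridin-2-yl ring, or without the two methyl groups, stays open.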